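Dimethylamino for imidazolyl on the butynyl chain

The compounds below may be only part of what the source reports. "The series", "measured", "known", "first", "only" and "open" are said of these compounds alone.

Compound 1 `CC(=O)N(C)CC#CCN(C)C` gives > 10 mg/kg as a limit
Compound 2 `COC(=O)N(C)CC#CCn1ccnc1` gives > 100 mg/kg as a limit

In a functional assay on the whole organism for antagonist activity, with Mus musculus as the target (on this read-out lower numbers stand for an effect already at smaller amounts and higher numbers for an effect only at larger amounts of compound), compound 2 has > 100 mg/kg as a limit and no number. Compound 3 `COC(=O)N(C)CC#CCN(C)C` carries dimethylamino in place of 1H-imidazol-1-yl on a saturated chain carbon bound to a triple-bonded carbon. Among the compounds with values here, no measured step shows what this change does. Within the data shown here, compound 1, which also bears dimethylamino, has > 10 mg/kg as its limit and is the only guide. The expected step of an at least 5.0-fold lower number from compound 2 to compound 3 (0.69 log units; beyond the scatter) runs towards smaller doses, beyond the scatter. The estimate for compound 3 is 20 mg/kg with an estimated range from 3 mg/kg to 100 mg/kg in this assay.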

Compound 3, dose for half-maximal effect: > 30 mg/kg
Compound 3 ended at the assay's limit; the forecaster's own chance of this, stated with the estimate: 55%; at least 1.5-fold (0.17 log units) between middle value and limit.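

In this assay compound 3 gives > 30 mg/kg, a limit of the assay. Compound 1 and compound 2 also stand at limits, and the steps from each to compound 3 cannot be read. Going by these compounds, the size of either change on the dose remains open.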